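This account rests on a few compounds, and the source may have more. Where it says the series, first, only, none or still open, it means among the compounds named here.

Measured in a toxicity assay on KB cells (Homo sapiens) for cytotoxicity, read by fluorescence, with a stated time of 3 days; a higher number here means that more compound is needed for the effect, a lower number that less compound is needed:
- compound 1 `CCCCOC(=O)CNC(=O)[C@H](CSc1ccc([N+](=O)[O-])cc1[N+](=O)[O-])NC(=O)CC[C@H](NC(=O)CC(C)C)C(=O)OCCCC`: 59.6 uM
- compound 2 `CCCCOC(=O)CNC(=O)[C@H](CSc1ccc([N+](=O)[O-])cc1[N+](=O)[O-])NC(=O)CC[C@H](NC(=O)OC)C(=O)OCCCC`: > 300 uM (a limit of the assay, not a number)
- compound 3 `CCCCOC(=O)CNC(=O)[C@H](CSc1ccc([N+](=O)[O-])cc1[N+](=O)[O-])NC(=O)CC[C@H](NC(=O)CCc1c[nH]c2ccccc12)C(=O)OCCCC`: 26 uM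

Among the measured compounds shown here, compound 3 has the lowest of the two true numbers, and the only other true number gives a 2.3-fold lower number from compound 1 to compound 3 (0.36 log units; beyond the scatter). The value of compound 2 is a limit, as the limit of > 300 uM in this assay, at which 1 of the 3 values shown sits, records.

Compound 4 `CCCCOC(=O)CNC(=O)[C@H](CSc1ccc([N+](=O)[O-])cc1[N+](=O)[O-])NC(=O)CC[C@H](NC(=O)COc1ccccc1)C(=O)OCCCC` has not yet been measured. It differs from compound 3 by phenoxy in place of (1H-indol-3-yl)methyl on a saturated chain carbon bound to a carbonyl carbon.

The measured steps all concern this same end of the molecule. Two of them are an at least 5.0-fold higher number from compound 1 to compound 2 (0.70 log units; beyond the scatter) and an at least 11-fold lower number from compound 2 to compound 3 (1.06 log units; beyond the scatter), so changing the group here can matter a great deal. Compound 4 keeps a carbon link to the carbonyl, as compound 1 does, rather than the methoxy of compound 2. It is therefore expected to fall nearer the true numbers, and the modest 2.3-fold lower number from compound 1 to compound 3 (0.36 log units; beyond the scatter) is the better guide to size.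

The change expected in this assay is small and toward a higher number: a 1.7-fold higher number from compound 3 to compound 4 (0.24 log units; within the scatter). The estimate for compound 4 is 45 uM, with an expected range from 18 uM to 120 uM.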

Compound 4, concentration for half-maximal effect: > 300 uM
Compound 4: only a limit was reported; the forecaster's own chance of this, stated with the estimate: 10%; at least 6.6-fold (0.82 log units) between middle value and limit.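

In this assay, keeping an aromatic ring at this end of the molecule is not enough to hold the number down, since phenoxy carries one and still gives a large rise (an at least 11-fold higher number from compound 3 to compound 4 (1.06 log units; beyond the scatter)). The isopropyl of compound 1 holds no ring, yet phenoxy in its place also raises the number (an at least 5.0-fold higher number from compound 1 to compound 4 (0.70 log units; beyond the scatter)), so among these compounds neither a ring nor a larger group tracks the lower numbers. The value of compound 4 is a limit and so is the value of compound 2, so the step between them cannot be read, and these two compounds, the only ones shown with an oxygen in the group at this position, sit together: (the limit of > 300 uM in this assay, at which 2 of the 4 values shown sit).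

These four compounds cannot separate the effect of that oxygen from the loss of (1H-indol-3-yl)methyl. Phenoxy changes both at once. A 2-phenylethyl group, with a carbon in place of the oxygen, would pull the two apart, while an amine or a carboxylic acid at this position remains an open case.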